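The source may report more compounds than this note shows. Statements on the series, on what has been measured and on what is new or still open speak of the compounds shown alone.

In a functional assay on MCF7 cells (Homo sapiens) for inhibition, read by colorimetric assay and MTT assay, with a stated time of 72 h (a lower number here means a stronger inhibitor, a higher number a weaker inhibitor), compound 2 `Cc1ccc(-c2nnc(Nc3csc(-c4ccccc4)c3)s2)cc1` gives 34000 nM, the only plain number among the two results shown. Compound 1 `COc1ccc(-c2cc(Nc3nnc(-c4ccc(C)cc4)s3)cs2)cc1` returns only a limit of the assay, > 100000 nM. Among the compounds with values here, the single measured step, an at least 2.9-fold lower number from compound 1 to compound 2 (0.46 log units; beyond the scatter), starts from the limit of > 100000 nM in this assay, at which 1 of the 2 values shown sits, and is at least modest. Compound 3 `Oc1ccc(-c2nnc(Nc3csc(-c4ccccc4)c3)s2)cc1` differs from compound 2 by hydroxy in place of methyl on an aromatic carbon. Within the data shown here, no measured step alters this group, so the step from compound 1 to compound 2 bears on it only loosely, and the step of a 1.1-fold lower number from compound 2 to compound 3 (0.05 log units; within the scatter) is expected to remain within the scatter in this assay. Compound 3 is therefore estimated at 30000 nM, with a range from 8000 nM to 100000 nM.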

Compound 3, half-maximal inhibitory concentration: 24000 nM
For compound 3 the middle estimate is 1.3-fold (0.10 log units) above the measured one, within the range that was stated.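

In this assay, the change from 4-methylphenyl to 4-hydroxyphenyl gives a 1.4-fold lower number from compound 2 to compound 3 (0.15 log units; within the scatter), so at this position hydroxy and methyl cannot be told apart. Within the data shown here, this is the first reading at this position, since the only earlier step changed another place in the molecule.

On these data alone, whether an amine, a carboxylic acid or a longer chain here would move the number beyond the scatter stays open. The size of the earlier step also stays open, since the result for compound 1 is only a limit of the assay: the limit of > 100000 nM in this assay, at which 1 of the 3 values shown sits.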